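A few compounds are considered here, and "the series" means these few. Any claim that something is new, unique, unknown or untested is made for them only; others in the source may bear on it.

Compound 1, `CN1CCC(c2ccc3c(c2)oc(=O)n3C(=O)NCCCCc2ccccc2)CC1=O`, gives 105 nM.
Compound 2, `CCOCCNC(=O)n1c(=O)oc2cc(C3CCN(C)CC3)ccc21`, gives 1050 nM.
Compound 3, `CC(=O)N1CCc2oc(=O)n(C(=O)NCCCCc3ccccc3)c2C1`, gives 293 nM.

These three compounds have been tested in an assay on HEK293 cells for inhibition of acid ceramidase (Homo sapiens), read by fluorescence, with stated times of 10 min and 3 h; a lower number here means a stronger inhibitor, a higher number a weaker inhibitor. Among them compound 1 stands at the lowest number, so it is the strongest inhibitor of the three. Compound 3 is the nearest to it, yet its higher number lies beyond the scatter of the measurement, and compound 2, the furthest, lies well beyond it. All three share the same core, and the differences between them sit on the outer groups.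

The next compound, compound 4, is `O=C(NCCCCc1ccccc1)n1c(=O)oc2cc(C3CCCCC3)ccc21`. It differs from compound 1 in one place: cyclohexyl in place of 1-methyl-2-oxopiperidin-4-yl on an aromatic carbon. Going by the values given here, no measured pair shows a change of this kind, so the size of the step has to be guessed from what the three compounds show rather than from a direct comparison. The three compounds show that alterations on the outer groups can move the number by large amounts, as the gap between compound 1 and compound 2 does, while other alterations move it by less.

A step from compound 1 to compound 4 of a 2.1-fold higher number from compound 1 to compound 4 (0.32 log units; beyond the scatter) is expected, a modest move toward a weaker inhibitor that is at the edge of the scatter. Compound 4 is therefore estimated to give 220 nM in this assay, with a range from 60 nM to 900 nM.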

Compound 4, half-maximal inhibitory concentration: 89 nM
Estimate against measurement, compound 4: 2.5-fold (0.39 log units) above, and the stated range covers the measured number.
By their numbers in this assay, from the lowest: compounds 4 and 1 (each within the scatter of the next); then compound 3; then compound 2.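

In this assay the exchange of 1-methyl-2-oxopiperidin-4-yl for cyclohexyl on this aromatic carbon gives a 1.2-fold lower number from compound 1 to compound 4 (0.07 log units; within the scatter) and so leaves compound 1 and compound 4 indistinguishable. The earlier compounds shown here could not show this: with the ring size kept, the ring nitrogen, the methyl group on it and the carbonyl with its hydrogen-bond acceptor can all go, leaving a ring of carbon only, with no measurable change in this pair, so none of these features is needed here to reach this level of inhibition. Nothing available explains why the number holds steady through this change.

The compounds shown leave open whether this position accepts a group other than a six-membered non-aromatic ring, such as a phenyl ring, a small cyclopropyl ring or an open butyl chain. Also open, as far as these compounds go, is whether a carboxylic acid or a primary amine attached to the cyclohexyl ring of compound 4 would keep the number where it is or move it toward a weaker inhibitor.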